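This account rests on a few compounds, and the source may have more. Where it says the series, first, only, none or still open, it means among the compounds named here.

- Compound 1 `CNC(=O)c1cc(Oc2ccc(C(=O)/C=C/c3ccc(OC)c(OC)c3OC)cc2)ccn1`: "not determined" (no result reported)
- Compound 2 `CNC(=O)c1cc(Oc2ccc(C(=O)/C=C/c3ccc(Br)cc3)cc2)ccn1`: > 50000 nM
- Compound 3 `CNC(=O)c1cc(Oc2ccc(C(=O)/C=C/c3ccc(F)cc3Cl)cc2)ccn1`: 21100 nM

In a functional assay on A549 cells (Homo sapiens) for cytotoxicity, read by MTT assay, with a stated time of 72 h (on this read-out lower numbers stand for stronger inhibition and higher numbers for weaker inhibition), compound 2 gives > 50000 nM, which is a limit of the assay and not a number. Compound 2 therefore stands at the limit of > 50000 nM in this assay, at which 1 of the 3 values shown sits. Compound 4 `CNC(=O)c1cc(Oc2ccc(C(=O)/C=C/c3ccccc3)cc2)ccn1` differs from it by one change: hydrogen in place of bromo on an aromatic carbon. For the measured compounds named here, only one measured step bears on this, an at least 2.3-fold lower number from compound 2 to compound 3 (0.37 log units; beyond the scatter), and it also swaps groups on that aromatic ring. On that evidence, a modest step to a lower number is expected, though compound 4 may well stay at the limit. The step expected is an at least 1.2-fold lower number from compound 2 to compound 4 (0.09 log units; that floor lies within the scatter). The estimate for compound 4 is 40000 nM, with an expected range of 15000 nM to 100000 nM.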

Compound 4, half-maximal inhibitory concentration: 5040 nM
Beside the measured number, compound 4's estimate is 7.9-fold (0.90 log units) above it, and the stated range ends above it.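

Compound 2 stands at a limit of the assay, > 50000 nM, and not at a number. In this assay, hydrogen in place of bromo gives an at least 9.9-fold lower number from compound 2 to compound 4 (0.99 log units; beyond the scatter), so this aromatic carbon needs no halogen for a measurable effect on the cells. The phenyl ring also outdoes the ring carrying two halogens, with a 4.2-fold lower number from compound 3 to compound 4 (0.62 log units; beyond the scatter), which the earlier comparison between halogen-bearing rings could not show. The compounds shown leave open whether an amine or a carboxylic acid in place of that hydrogen would lower the number further or raise it.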